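Swapping pyridin-2-yl for pyridazin-3-yl on the amide nitrogen

The source may report more compounds than this note shows. Statements on the series, on what has been measured and on what is new or still open speak of the compounds shown alone.

For the measured compounds named here, compound 2 `CC(C)[C@H](C(=O)Nc1ccccn1)c1ccc(Cl)cc1` is the only member of this series with a number in a functional assay on CHO cells for agonist activity at Free fatty acid receptor 2 (Homo sapiens), read by cAMP accumulation; a higher number here means a larger maximal response, a lower number a smaller maximal response: compound 2 reaches 92%. Compound 1 `CC(C)[C@H](C(=O)NCc1ccccc1)c1ccc(Cl)cc1` is reported in this assay only as a limit, where compound 1 gives < 30%. Going by the values given here, the single measured step is large, a number at least 62 percentage points higher from compound 1 to compound 2 (beyond the scatter), and its true size is open at the lower end, since compound 1 sits at the limit (the limit of < 30% in this assay, at which 1 of the 2 values shown sits).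

Compound 3 `CC(C)[C@H](C(=O)Nc1cccnn1)c1ccc(Cl)cc1` is the next step from compound 2: pyridazin-3-yl in place of pyridin-2-yl on an amide-type nitrogen. Among the compounds with values here, no measured step concerns this exchange directly; the one step in hand compares benzyl with pyridin-2-yl, and it only shows that a six-membered aromatic ring bound straight to the amide nitrogen goes with a high maximal response in compound 2. Pyridazin-3-yl keeps that arrangement, so compound 3 is expected to stay close to compound 2, with a step of a number 10 percentage points lower from compound 2 to compound 3 (within the scatter) that is expected to fall within the scatter or a little below it. For compound 3 the estimate in this assay is 82%, with a range from 45% to 105%.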

Compound 3, largest response reached (reported as efficacy), in percent of the reference or control that the assay uses: 101%
Compound 3: middle estimate off by 19 percentage points, on the low side; the range from low to high includes it.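

At the amide-type nitrogen, pyridin-2-yl and pyridazin-3-yl cannot be told apart in this assay, with a number 9 percentage points higher from compound 2 to compound 3 (within the scatter), so this position accepts a second hetero atom in the six-membered aromatic ring, and the second hydrogen-bond acceptor counted with it, without a measurable loss of maximal response. The large gap to the benzyl amide now appears with a second ring as well, a number at least 71 percentage points higher from compound 1 to compound 3 (beyond the scatter), which shows that the high response of compound 2 is not peculiar to pyridin-2-yl. Compound 1 is reported only as a limit, and the true size of this step stays open: the limit of < 30% in this assay, at which 1 of the 3 values shown sits.

Both rings that give a high response carry ring nitrogen and sit directly on the amide nitrogen, whereas benzyl has no ring nitrogen and a carbon link, so the compounds shown cannot separate these two differences, and a plain phenyl group on the amide nitrogen would be needed to do so. Going by these compounds, it also remains open how far this position extends to other groups, such as a pyrimidinyl ring, a saturated piperidine ring or a ring bearing a carboxylic acid.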